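Removing a Fluoro Group: From Compound 3 to Compound 4

This account rests on a few compounds, and the source may have more. Where it says the series, first, only, none or still open, it means among the compounds named here.

Measured compounds:
compound 1 `Cc1ccnc(/C(N)=N/NC(=S)N2CCSCC2)c1`, which in a functional assay on MCF7 cells (Homo sapiens) for cytotoxicity, read by MTT assay, with a stated time of 72 h, tested at 3 uM (on this read-out lower numbers stand for less inhibition of growth and higher numbers for more inhibition of growth at the one concentration tested), gives 33.8%
compound 2 `Cc1ccnc(/C(N)=N/NC(=S)N2CCCCCC2)c1`, which in this assay gives 36.3%
compound 3 `N/C(=N\NC(=S)N1CCN(c2ccccn2)CC1)c1ccc(F)cn1`, which in this assay gives 27.1%

All three share a thiosemicarbazide-like core and differ in the ring attached to the thiocarbonyl and in the aromatic group at the other end. On the numbers as they stand, compound 3 sits at the low end of the three, but the gap to compound 1 and the gap to compound 2 are both within the scatter of repeated measurements, so the three cannot be told apart with any confidence.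

Compound 4 `N/C(=N\NC(=S)N1CCN(c2ccccn2)CC1)c1ccccn1` has not yet been measured. It differs from compound 3 in one place: hydrogen in place of fluoro on an aromatic carbon. Among the compounds with values here, no pair among the measured compounds shows this same change, so there is no step to lean on.

Given that no measured step isolates this change, the step from compound 3 to compound 4 in this assay is expected to be a number 0.1 percentage points lower from compound 3 to compound 4 (within the scatter), that is, nothing beyond the scatter. Compound 4 is therefore expected to give about 27% in this assay, within a range from 14% to 40%.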

Compound 4, percent growth inhibition at one concentration: 37.2%
Compound 4: the middle estimate sits 10.2 percentage points below what was measured; low and high end bracket the measured number.
By their numbers in this assay, from the lowest: compounds 3, 1, 2 and 4 (each within the scatter of the next, the first and the last beyond it).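

Within the data shown here, for the first time, a single change can be read on its own: in this assay going from 5-fluoropyridin-2-yl to pyridin-2-yl gives a number 10.1 percentage points higher from compound 3 to compound 4 (beyond the scatter) and no other difference between the two structures competes with it. The step is modest, but it shows that what sits on this aromatic carbon, two atoms from the ring nitrogen and para to a large group, can matter for this read-out, with hydrogen going along with more inhibition of growth than fluoro in this one pair. No measurement at hand says why the number moves.

Among these compounds, this is one pair at one concentration, so it remains open whether the same swap would give a similar step with a different ring on the thiocarbonyl end, such as the one in compound 1 or compound 2. On these data alone, it also remains open whether a chloro or a methoxy group at this position would read like fluoro, like hydrogen, or like neither.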